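The source may hold more compounds than are shown below. What is called first, only, known or untested is meant among the compounds shown, and "the series" means these compounds.

Measured compounds:
compound 1 `CN(c1ccc(NC(=O)c2ccc(I)cc2)cc1OCc1cc(Cl)ccc1Cl)S(C)(=O)=O` with 660 nM
compound 2 `CN(c1ccc(NC(=O)c2ccc3ccccc3c2)cc1OCc1cc(Cl)ccc1Cl)S(C)(=O)=O` with 2210 nM
compound 3 `CCCCCCOc1cc(NC(=O)c2ccc(I)cc2)ccc1N(C)S(C)(=O)=O` with 12700 nM

In a functional assay on SK-BR-3 cells (Homo sapiens) for antiproliferative activity, read by MTT assay, with a stated time of 48 h (on this read-out lower numbers stand for stronger inhibition and higher numbers for weaker inhibition), compound 1 gives 660 nM, the lowest of the three numbers. Compound 2 differs from compound 1 by naphthalen-2-yl in place of 4-iodophenyl on a carbonyl carbon, and this step raised the number: a 3.3-fold higher number from compound 1 to compound 2 (0.52 log units; beyond the scatter). Compound 3 differs from compound 1 in its core, by pentyl in place of 2,5-dichlorophenyl on a saturated chain carbon bound to an oxygen on an aromatic ring, and here the rise was far greater: a 19-fold higher number from compound 1 to compound 3 (1.28 log units; beyond the scatter). In this assay compound 3 gives 12700 nM, the highest of the three numbers.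

Compound 4 `CCCCCCOc1cc(NC(=O)c2ccc3ccccc3c2)ccc1N(C)S(C)(=O)=O` has not yet been measured in this assay. It is related to compound 3 by naphthalen-2-yl in place of 4-iodophenyl on a carbonyl carbon, and the place is worded the same as in the pair of compound 1 and compound 2, so this is the same change made on the other core. Because the change raised the number once, in a 3.3-fold higher number from compound 1 to compound 2 (0.52 log units; beyond the scatter), a rise of similar size from compound 3 is expected, with a 3.1-fold higher number from compound 3 to compound 4 (0.50 log units; beyond the scatter) as the estimated step. For compound 4 the estimate is 40000 nM, expected to fall between 15000 nM and 110000 nM.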

Compound 4, half-maximal inhibitory concentration: 64300 nM
Beside the measured number, compound 4's estimate is 1.6-fold (0.21 log units) below it; the range from low to high includes it.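

In this assay, naphthalen-2-yl in place of 4-iodophenyl on a carbonyl carbon gave a 5.1-fold higher number from compound 3 to compound 4 (0.70 log units; beyond the scatter), and this step agrees with its counterpart on the other core: the same change on two cores in this assay, a 3.3-fold higher number (0.52 log units; beyond the scatter) from compound 1 to compound 2 and a 5.1-fold higher number (0.70 log units; beyond the scatter) from compound 3 to compound 4, 1.5-fold (0.18 log units) apart, within the scatter of two such steps. Pentyl in place of 2,5-dichlorophenyl on a saturated chain carbon bound to an oxygen on an aromatic ring gave a 29-fold higher number from compound 2 to compound 4 (1.46 log units; beyond the scatter), and this step likewise agrees with its counterpart: the same change on two cores in this assay, a 19-fold higher number (1.28 log units; beyond the scatter) from compound 1 to compound 3 and a 29-fold higher number (1.46 log units; beyond the scatter) from compound 2 to compound 4, 1.5-fold (0.18 log units) apart, within the scatter of two such steps. Each change therefore carried from one core to the other with much the same size here, but this rests on a single set of four compounds in one cell line and does not show that the steps would stay the same with other groups or on other cores.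

The compounds shown leave open whether an amine or a carboxylic acid in place of the iodine, or a longer chain in place of pentyl, would carry over in the same way. They also say nothing about how these steps would look in any other cell line.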